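Hydroxypyrazole amide in a series at the assay ceiling

The source may hold more compounds than are shown below. What is called first, only, known or untested is meant among the compounds shown, and "the series" means these compounds.

Compound 2 `COc1nsnc1C(=O)Nc1cc(C(F)(F)F)cc(C(F)(F)F)c1` is the anchor for this step. In an assay on isolated protein for inhibition of mitogen-activated protein kinase kinase kinase 14 (Homo sapiens), read by ADP-Glo, with a stated time of 60 min, in the presence of a further agent that is not named here (a lower number here means a stronger inhibitor, a higher number a weaker inhibitor), compound 2 gives > 100000 nM, which is a limit of the assay and not a number. Compound 1 `O=C(Nc1cc(C(F)(F)F)cc(C(F)(F)F)c1)c1nsnc1O` gives > 100000 nM in this assay, again a limit. Compound 3 `O=C(Nc1cc(C(F)(F)F)cc(C(F)(F)F)c1)c1nonc1O` gives > 100000 nM in this assay, likewise a limit. Accordingly a step that the two limits leave unreadable from compound 1 to compound 2, a step that the two limits leave unreadable from compound 1 to compound 3 and a step that the two limits leave unreadable from compound 2 to compound 3 are all unreadable, because of the limit of > 100000 nM in this assay, at which 3 of the 3 values shown sit. Compound 4 `Cc1c(C(=O)Nc2cc(C(F)(F)F)cc(C(F)(F)F)c2)c(O)nn1C` differs from compound 2 in the group on the carbonyl carbon.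

a group of 8 heavy atoms (5 carbon, 2 nitrogen, 1 oxygen; one five-membered aromatic ring with 2 hetero atoms) in place of a group of 7 heavy atoms (3 carbon, 2 nitrogen, 1 oxygen, 1 sulfur; one five-membered aromatic ring with 3 hetero atoms), on a carbonyl carbon

Within the data shown here, none of the measured steps reads the effect of exchanging the ring on the carbonyl carbon, so no step size is expected in this assay in either direction beyond the scatter, and the three values shown give no foothold for a gain. Compound 4 is therefore expected to give 150000 nM in this assay, with a range of 20000 nM to 1000000 nM. The estimated step is a step that the limit leaves unreadable from compound 2 to compound 4, most probably again reported as a limit.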

Compound 4, half-maximal inhibitory concentration: > 100000 nM
Compound 4: only a limit was reported; the forecaster's own chance of this, stated with the estimate: 85%; the middle value is on the limit's open side.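

The steps from compound 1, compound 2 and compound 3 to compound 4 cannot be read, because each value is a limit and not a number: the limit of > 100000 nM in this assay, at which 4 of the 4 values shown sit. The compounds shown leave open whether any group on the carbonyl carbon of the shared core gives a measurable value in this assay.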